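Ethynyl in place of ethyl in compound 3

The compounds below may be only part of what the source reports. "The series", "measured", "known", "first", "only" and "open" are said of these compounds alone.

In a functional assay on SK-MEL-28 cells (Homo sapiens) for inhibition, read by colorimetric assay and MTT assay, with a stated time of 72 h (on this read-out lower numbers stand for stronger inhibition and higher numbers for weaker inhibition), compound 1 `C=CCCCCOc1ccc(OC)cc1-c1cnc(OCCC=C)n1C` gives 62000 nM, compound 2 `CCCCOc1ncc(-c2ccccc2OC)n1C` gives 82000 nM and compound 3 `CCCCCCOc1ncc(-c2ccccc2OC)n1C` gives 43000 nM. These three numbers lie within the scatter of one another, so compound 3 is not separated from either of the other two.

The next compound is compound 4 `C#CCCCCOc1ncc(-c2ccccc2OC)n1C`, and the change is ethynyl in place of ethyl on a saturated chain carbon, four bonds along the chain from an oxygen on an aromatic ring. Ethynyl replaces ethyl on a saturated chain carbon, four bonds along the chain from an oxygen on an aromatic ring. Cut one bond further out, this reads pentyl to pent-4-yn-1-yl.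

Among the compounds with values here, only one measured step bears on this place: a 1.9-fold lower number from compound 2 to compound 3 (0.28 log units; within the scatter), where ethyl replaces hydrogen. That step stays within the scatter. Compound 1 differs from compound 3 in more than one place and offers no clean comparison. Within the data shown here, no measured pair exchanges ethyl for ethynyl, so the evidence is indirect.

The expectation rests on the small size of a 1.9-fold lower number from compound 2 to compound 3 (0.28 log units; within the scatter) and on the value of compound 3 at 43000 nM. No step beyond the scatter is expected in this assay, in either direction. The expected step is a 1.0-fold higher number from compound 3 to compound 4 (0.02 log units; within the scatter). For compound 4 the estimated value is 45000 nM, with an expected range from 22000 nM to 90000 nM.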

Compound 4, half-maximal inhibitory concentration: 38000 nM
Compound 4: the middle estimate sits 1.2-fold (0.07 log units) above what was measured; measured number inside the range.
By their numbers in this assay, from the lowest: compounds 4, 3, 1 and 2 (each within the scatter of the next, the first and the last beyond it).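

In this assay, ethynyl in place of ethyl on a saturated chain carbon, four bonds along the chain from an oxygen on an aromatic ring, gives a 1.1-fold lower number from compound 3 to compound 4 (0.05 log units; within the scatter) and so does not separate pentyl from pent-4-yn-1-yl at this place. Set against hydrogen at the same place, ethynyl gives a 2.2-fold lower number from compound 2 to compound 4 (0.33 log units; beyond the scatter) and is the first change here to pass the scatter, though only modestly, whereas ethyl in place of hydrogen gives a 1.9-fold lower number from compound 2 to compound 3 (0.28 log units; within the scatter) and stays within it. No measurement shown accounts for these numbers.

Open, going by these compounds, is whether an amine, a carboxylic acid or a longer chain at this place would move the number beyond the scatter from compound 3 or compound 4. Also open is whether ethynyl in place of ethyl reads the same on a core carrying a different group on the aromatic ring, such as a fluorine or a nitrile, since all the steps shown here rest on the core of compound 2.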